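The source may report more compounds than this note shows. Statements on the series, on what has been measured and on what is new or still open speak of the compounds shown alone.

In a functional assay on BGC-823 cells (Homo sapiens) for antiproliferative activity, read by MTT assay, with a stated time of 72 h (a lower number here means a stronger inhibitor, a higher number a weaker inhibitor), compound 1 (`O=C(Nc1cccc(I)c1)C(Cl)Cl`) gives 58800 nM and compound 2 (`COc1cccc(NC(=O)C(Cl)Cl)c1`) gives 179000 nM. Compound 3 (`Cc1ccc(NC(=O)C(Cl)Cl)cc1`) stands at "not determined" (no result reported), so it offers no number to step from. Compound 4 (`O=C(Nc1ccc(SC(F)(F)F)cc1)C(Cl)Cl`) carries (trifluoromethyl)sulfanyl in place of methyl on an aromatic carbon. Going by the values given here, the only measured step, a 3.0-fold higher number from compound 1 to compound 2 (0.48 log units; beyond the scatter), swaps iodo for methoxy and involves neither group in this change, so it bears only as a rough gauge of spread. No size or direction can be expected for the step from compound 3 in this assay. The estimate instead leans on the level of compound 1 at 58800 nM and compound 2 at 179000 nM. For compound 4 the expected value is 80000 nM, with an estimated range of 25000 nM to 250000 nM.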

Compound 4, half-maximal inhibitory concentration: 203000 nM
Estimate against measurement, compound 4: 2.5-fold (0.40 log units) below; the measured number falls inside the stated range.
By their numbers in this assay, from the lowest: compound 1; then compounds 2 and 4 (each within the scatter of the next).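

Going by these compounds alone, compound 3 offers no number to step from, so no step to compound 4 can be read in this assay. No evidence on cause accompanies this result. The compounds shown leave open what (trifluoromethyl)sulfanyl in place of methyl does on the shared core.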